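From 3-chlorobenzyl to 2-chlorobenzyl on a shared core

The compounds below may be only part of what the source reports. "The series", "measured", "known", "first", "only" and "open" are said of these compounds alone.

In a functional assay on U-251 cells (Homo sapiens) for antiproliferative activity, read by MTT assay, with a stated time of 24 h (a higher number here means a weaker inhibitor, a lower number a stronger inhibitor), compound 3 (`COc1cc(OC)c(-c2coc3cc(OCc4cccc(Cl)c4)ccc3c2=O)cc1OC`) stands at > 10000 nM as a limit and not a number. Compound 1 (`COc1cc(OC)c(-c2coc3cc(OCC(=O)c4cccc(C(F)(F)F)c4)ccc3c2=O)cc1OC`) gives > 10000 nM as a limit too. Compound 2 (`COc1cc(OC)c(-c2coc3cc(OCc4ccccc4F)ccc3c2=O)cc1OC`) gives 2890 nM as a measured number.

The change to compound 4 (`COc1cc(OC)c(-c2coc3cc(OCc4ccccc4Cl)ccc3c2=O)cc1OC`) puts 2-chlorophenyl in place of 3-chlorophenyl on a saturated chain carbon bound to an oxygen on an aromatic ring and leaves the atoms the same but joined differently. The nearest measured step is an at least 3.4-fold higher number from compound 2 to compound 3 (0.53 log units; beyond the scatter) and changes the halogen along with its numbering on the ring, so it isolates neither. Among the measured compounds shown here, the step of an at least 3.4-fold lower number from compound 1 to compound 2 (0.53 log units; beyond the scatter) also ends at the only measured number, while a step that the two limits leave unreadable from compound 1 to compound 3 gives no size.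

Compound 4 shares the 2-substituted naming with compound 2 at 2890 nM but keeps the chlorine of compound 3. A modest move to a lower number is therefore expected in this assay although the result may still be only a limit. The expected step is an at least 2.2-fold lower number from compound 3 to compound 4 (0.34 log units; beyond the scatter) on this estimate. For compound 4 the half-maximal inhibitory concentration is estimated at 4500 nM with an expected range from 1500 nM to 13000 nM in this assay.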

Compound 4, half-maximal inhibitory concentration: > 10000 nM
Compound 4: only a limit was reported (the forecaster's own chance of this, stated with the estimate: 30%); at least 2.2-fold (0.34 log units) between middle value and limit.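

In this assay, putting chloro in place of fluoro on an aromatic carbon gives an at least 3.4-fold higher number from compound 2 to compound 4 (0.53 log units; beyond the scatter), and this is the first step shown in which the halogen changes while its place on the ring stays the same. The earlier step from the 2-fluorophenyl to the 3-chlorophenyl compound changed both at once, whereas this one shows that the halogen alone is enough to lose the measured number, and that a 2-substituted ring does not keep it. The steps from compound 3 to compound 4 and from compound 1 to compound 4 cannot be read, since both ends of each are limits, so among these compounds only compound 2 gives a measured number: the limit of > 10000 nM in this assay, at which 3 of the 4 values shown sit.

As far as these compounds go, how far compound 3 and compound 4 lie beyond that limit stays unknown, so the effect of moving the chlorine from 3-chlorophenyl to 2-chlorophenyl remains open. Also open, from the compounds shown here alone, is whether the number of compound 2 depends on a halogen at all, and how a phenyl carrying no halogen, an amine on the ring or a longer chain would read.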